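A few compounds are considered here, and "the series" means these few. Any claim that something is new, unique, unknown or untested is made for them only; others in the source may bear on it.

Measured in an ADME assay on MT4 cells (Homo sapiens) for cytotoxicity, read by MTT assay, with a stated time of 96 h; a higher number here means that more compound is tolerated, a lower number that less compound is tolerated:
- Compound 1 `NS(=O)(=O)c1ccc(N2N=C(c3ccc(OCc4ccccc4)cc3)CC2c2ccc(F)cc2)cc1`: > 100000 nM
- Compound 2 `Cc1cccc(C2CC(c3ccc(Oc4ccccc4)cc3)=NN2c2ccc(S(N)(=O)=O)cc2)c1`: 35000 nM
- Compound 3 `NS(=O)(=O)c1ccc(N2N=C(c3ccc(Oc4ccccc4)cc3)CC2c2ccc(F)cc2)cc1`: 33000 nM

The value of compound 1 is a limit of the assay and not a number. Compound 1 stands at the limit of > 100000 nM in this assay, at which 1 of the 3 values shown sits.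

Compound 4 `NS(=O)(=O)c1ccc(N2N=C(c3ccc(OCc4ccccc4)cc3)CC2c2cccc(Cl)c2)cc1` keeps the benzyl group on the oxygen and differs from compound 1 at one place: 3-chlorophenyl in place of 4-fluorophenyl on a saturated ring carbon. In words, 3-chlorophenyl stands in place of 4-fluorophenyl on a saturated ring carbon, next to the ring nitrogen.

Two measured steps are available. The closer one is at this same carbon, where 4-fluorophenyl replaces 3-methylphenyl: a 1.1-fold lower number from compound 2 to compound 3 (0.03 log units; within the scatter). It lies within the scatter, but it was measured with phenyl on the oxygen, and 3-chlorophenyl itself has no measured value. The other, an at least 3.0-fold lower number from compound 1 to compound 3 (0.48 log units; beyond the scatter), lies beyond the scatter, but it concerns the group on the oxygen, which does not change here.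

No step beyond the scatter is therefore expected in this assay. The expected step is a number no higher from compound 1 to compound 4 (the limit leaves the size open). A report as a limit is expected to be somewhat more likely than a number. For compound 4 the estimate is 100000 nM, with an expected range from 40000 nM to 250000 nM.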

Compound 4, half-maximal cytotoxic concentration: 36000 nM
Compound 4: the middle estimate sits 2.8-fold (0.44 log units) above what was measured; measured number below the stated range.
By their numbers in this assay, from the lowest: compounds 3, 2 and 4 (each within the scatter of the next). At a limit, above all of these: compound 1.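

In this assay, the saturated ring carbon next to the ring nitrogen now shows that a change there can move the number when benzyl sits on the oxygen: an at least 2.7-fold lower number from compound 1 to compound 4 (0.44 log units; beyond the scatter). Going by these compounds alone, the only earlier step at this carbon, measured with phenyl on the oxygen, gave no such signal: a 1.1-fold lower number from compound 2 to compound 3 (0.03 log units; within the scatter). The value of compound 1 is a limit and not a number, so the new step has a lower bound but no fixed size: the limit of > 100000 nM in this assay, at which 1 of the 4 values shown sits.

The two steps at this carbon differ both in the group on the oxygen and in the aryl group exchanged for 4-fluorophenyl, so they do not show whether the benzyl group, the 3-chlorophenyl group or their combination accounts for the contrast, and a pairing of 3-chlorophenyl with phenyl on the oxygen would be needed to separate them. Also open is how the number responds at this carbon to a group outside the substituted phenyl rings shown, such as a pyridine ring, or to a phenyl ring carrying an amine or a carboxylic acid.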